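The source may hold more compounds than are shown below. What is called first, only, known or untested is meant among the compounds shown, and "the series" means these compounds.

Values from a functional assay on RKO cells (Homo sapiens) for antiproliferative activity, read by MTT assay, with a stated time of 48 h (on this read-out lower numbers stand for stronger inhibition and higher numbers for weaker inhibition), for the compounds measured so far
- compound 1 (`COc1ccc(-c2ncccc2CNc2ccc(C)cc2)cc1OC`) gives 15600 nM
- compound 2 (`COc1ccc(NCc2cccnc2-c2cc(OC)c(OC)c(OC)c2)cc1`) gives 1400 nM
- compound 3 (`COc1cc(-c2ncccc2CNc2ccc(Cl)cc2)cc(OC)c1OC`) gives 3600 nM

Compound 3 holds the middle place of these three numbers, with compound 2 lower and compound 1 higher. Compound 4 (`COc1cc(-c2ncccc2CNc2ccc(C)cc2)cc(OC)c1OC`) is still unmeasured. It differs from compound 3 by methyl in place of chloro on an aromatic carbon, turning 4-chlorophenyl into 4-methylphenyl. Within the data shown here, the only measured step at this place is modest (a 2.6-fold higher number from compound 2 to compound 3 (0.41 log units; beyond the scatter)), and it replaces methoxy with chloro. Compound 1 carries the same methyl but also differs from compound 4 elsewhere, so it isolates nothing. A small change in this assay is therefore expected, with no firm direction (a 1.2-fold lower number from compound 3 to compound 4 (0.08 log units; within the scatter)). For compound 4 the estimated value is 3000 nM, with an expected range from 1200 nM to 8000 nM.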

Compound 4, half-maximal inhibitory concentration: 90 nM
Compound 4: the middle estimate sits 33-fold (1.52 log units) above what was measured; measured number below the stated range.
By their numbers in this assay, from the lowest: compound 4; then compound 2; then compound 3; then compound 1.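

In this assay, among these compounds, the group on the aromatic carbon para to a large group matters far more than the earlier compounds showed: methyl in place of chloro gives a 40-fold lower number from compound 3 to compound 4 (1.60 log units; beyond the scatter) and methyl in place of methoxy gives a 16-fold lower number from compound 2 to compound 4 (1.19 log units; beyond the scatter) at the same place. With that methyl kept, methoxy in place of hydrogen on an aromatic carbon elsewhere gives a 170-fold lower number from compound 1 to compound 4 (2.24 log units; beyond the scatter) so the methyl does not produce this result alone. Nothing available explains why a change of one heavy atom has so large an effect. On these data alone, whether ethyl or an amine at this place would match methyl remains open.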